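The compounds below may be only part of what the source reports. "The series", "measured", "known", "first", "only" and "open" are said of these compounds alone.

In a functional assay on HL-60 cells (Homo sapiens) for cytotoxicity (on this read-out higher numbers stand for weaker inhibition and lower numbers for stronger inhibition), compound 1 `C/C=C(/C)C(=O)O[C@@H]1/C(C)=C/[C@@]23O[C@@]2(C[C@H](C)[C@@H]3O)C(=O)[C@H](C)[C@H](O)[C@@H]2[C@H]([C@H]1OC)C2(C)C` gives < 10000 nM as a limit and not a number. Compound 2 `CCC(C)C(=O)O[C@@H]1[C@H]2[C@@H]([C@@H](OC(C)=O)[C@@H](C)C(=O)[C@@]34C[C@H](C)[C@H](O)[C@]3(/C=C(\C)[C@H]1OC(C)=O)O4)C2(C)C` gives < 10000 nM and this too is only a limit. The picture so far is the limit of < 10000 nM in this assay, at which 2 of the 2 values shown sit, and nothing finer. Compound 3 `C/C=C(/C)C(=O)O[C@@H]1/C(C)=C/[C@@]23O[C@@]2(C[C@@H](C)[C@H]3O)C(=O)[C@H](C)[C@H](O)[C@@H]2[C@H]([C@H]1OC)C2(C)C` has the same atoms and bonds as compound 1 and differs only in configuration as drawn: the two compounds have the same atoms and bonds and differ only in configuration as drawn: 2 of 12 stereo elements differ; a stereocentre at a saturated ring carbon is drawn S in compound 1 and R in compound 3; a stereocentre at a saturated ring carbon is drawn S in compound 1 and R in compound 3 with both saturated ring carbons drawn S in compound 1 and R in compound 3. No measured step sizes such a change, so no direction is favoured and the estimated step that the limit leaves unreadable from compound 1 to compound 3 is expected to stay within the scatter. In this assay compound 3 is expected near 6000 nM with an estimated range of 2000 nM to 18000 nM for now.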

Compound 3, half-maximal inhibitory concentration: < 10000 nM
Compound 3 was reported as a limit; the forecaster's own chance of this, stated with the estimate: 50%; the middle value is on the limit's open side.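

No step can be read from compound 1 to compound 3 in this assay, because both values are only limits: the limit of < 10000 nM in this assay, at which 3 of the 3 values shown sit. The compounds shown leave open whether this change of configuration alters potency in this assay, and what the actual values of all three compounds are.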